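Cell Tolerance Across Four Close Analogues

The source may report more compounds than this note shows. Statements on the series, on what has been measured and on what is new or still open speak of the compounds shown alone.

Compound 1 `CCCCSc1nc(C(C)c2c(F)cccc2Cl)c(CC)c(=O)[nH]1` was tested in an ADME assay on MT4 cells (Homo sapiens) for activation, read by MTT assay; on this read-out higher numbers stand for lower toxicity in this test and lower numbers for higher toxicity in this test. In this assay compound 1 gives > 3000 nM, which is a limit of the assay and not a number. Compound 2 `CCc1c(C(C)c2c(F)cccc2Cl)nc(SC2CCCC2)[nH]c1=O` differs from compound 1 by cyclopentyl in place of butyl on a sulfur. In this assay compound 2 gives > 3000 nM, again a limit of the assay. The step that the two limits leave unreadable from compound 1 to compound 2 therefore cannot be sized. Compound 3 `CCCCSc1nc(C(C)c2c(F)cccc2F)c(CC)c(=O)[nH]1` differs from compound 1 elsewhere in the molecule: fluoro in place of chloro on an aromatic carbon. In this assay compound 3 gives > 3000 nM, also a limit. The step that the two limits leave unreadable from compound 1 to compound 3 likewise cannot be sized, because of the limit of > 3000 nM in this assay, at which 3 of the 3 values shown sit.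

Compound 4 `CCc1c(C(C)c2c(F)cccc2F)nc(SC2CCCC2)[nH]c1=O` has not yet been measured. It differs from compound 3 by cyclopentyl in place of butyl on a sulfur, the same change that separates compound 1 from compound 2, made at the same place. Because (the limit of > 3000 nM in this assay, at which 3 of the 3 values shown sit), compound 4 is expected to sit at that limit as well, with an expected step that the limit leaves unreadable from compound 3 to compound 4. The estimate for compound 4 is 5000 nM, between 3000 nM and 20000 nM.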

Compound 4, half-maximal cytotoxic concentration: > 3000 nM
Compound 4: no number, only a limit (the forecaster's own chance of this, stated with the estimate: 85%); the middle value lies beyond the limit too.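

The result for compound 4 gives no new step that can be read: its steps from compound 3 and from compound 2 join limits to limits, so neither change can be sized in this assay: the limit of > 3000 nM in this assay, at which 4 of the 4 values shown sit.

The compounds shown leave open how far each of the four lies past that limit, and whether either change alters cell tolerance at all.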